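A few compounds are considered here, and "the series" means these few. Any claim that something is new, unique, unknown or untested is made for them only; others in the source may bear on it.

Measured so far in a functional assay on HEK293 cells (Homo sapiens) for cytotoxicity; a higher number here means that more compound is tolerated, a lower number that less compound is tolerated:

- Compound 1 `COc1ccc([C@H]2CC(=O)N(c3cccc(S(C)(=O)=O)c3)C2)cc1OC1CCCC1`: > 10000 nM (a limit)
- Compound 2 `COc1ccc([C@H]2CC(=O)N(c3cccc(NCC4CCOC4)c3)C2)cc1OC1CCCC1`: > 10000 nM (a limit)
- Compound 3 `COc1ccc([C@H]2CC(=O)N(c3cccc(NS(=O)(=O)c4cccc(C)c4)c3)C2)cc1OC1CCCC1`: > 10000 nM (a limit)

Compound 3 gives > 10000 nM, and this is a limit of the assay, not a number. It shares that position with the other two compounds: the limit of > 10000 nM in this assay, at which 3 of the 3 values shown sit. No order among the three can therefore be read.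

Compound 4 `COc1ccc([C@H]2CC(=O)N(c3cccc(NS(=O)(=O)c4c(Br)nn(C)c4Cl)c3)C2)cc1OC1CCCC1` keeps the shared core and changes one group, with 3-bromo-5-chloro-1-methyl-1H-pyrazol-4-yl in place of 3-methylphenyl on a sulfonyl sulfur. Going by the values given here, no measured compound carries this new group, so any forecast rests on indirect evidence.

The closest measured change is a step that the two limits leave unreadable from compound 2 to compound 3, which replaces a whole group on the same nitrogen. Two further changes are a step that the two limits leave unreadable from compound 1 to compound 3 and a step that the two limits leave unreadable from compound 1 to compound 2. None of these steps has a readable size, yet no change among the three compounds moved the result away from the limit.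

No step beyond the usual scatter is therefore expected, in either direction, and the estimated step is a step that the limit leaves unreadable from compound 3 to compound 4. For compound 4, the expected value in this assay is 12000 nM, with an estimated range of 5000 nM to 30000 nM.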

Compound 4, half-maximal cytotoxic concentration: > 10000 nM
Compound 4: no number, only a limit; the forecaster's own chance of this, stated with the estimate: 80%; the middle value is on the limit's open side.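

In this assay compound 4 gives > 10000 nM, which is a limit and not a number. Going by these compounds alone, no step from compound 1, compound 2 or compound 3 to compound 4 can be read, since all four share one position: the limit of > 10000 nM in this assay, at which 4 of the 4 values shown sit. Left open is how far apart the four compounds lie in this assay, and whether any of the exchanged groups changes the result at all.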